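Aryl exchange on the acetyl-bearing compound 3

The compounds below may be only part of what the source reports. "The series", "measured", "known", "first", "only" and "open" are said of these compounds alone.

In a functional assay on K562 cells (Homo sapiens) for cytotoxicity, read by MTT assay, with a stated time of 48 h (a higher number here means a weaker inhibitor, a lower number a stronger inhibitor), compound 1 `COc1cc(-n2c(-c3ccc(O)cc3)c[nH]c2=O)cc(OC)c1OC` gives > 50000 nM, which is a limit of the assay and not a number. Compound 2 `COc1ccc(-c2cn(C(=O)Nc3cc(OC)c(OC)c(OC)c3)c(=O)n2-c2cc(OC)c(OC)c(OC)c2)cc1O` gives > 50000 nM, again a limit. Among the measured compounds shown here, compound 3 `COc1cc(-n2c(-c3ccc(Br)cc3)cn(C(C)=O)c2=O)cc(OC)c1OC` gives 1000 nM, the only actual number so far. The other two values mark the limit of this assay, as the limit of > 50000 nM in this assay, at which 2 of the 3 values shown sit, records.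

The next compound to be tested is compound 4 `COc1ccc(-c2cn(C(C)=O)c(=O)n2-c2cc(OC)c(OC)c(OC)c2)cc1N`, which has 3-amino-4-methoxyphenyl in place of 4-bromophenyl on an aromatic carbon, next to the ring atom that bears a large group: 3-amino-4-methoxyphenyl in place of 4-bromophenyl on an aromatic carbon. The acetyl group stays in place, so the aryl exchange is the single difference.

For the measured compounds named here, no measured pair isolates this exchange or any other single change, so the expectation rests on judgement and remains loose. A step towards stronger inhibition in this assay, beyond the usual scatter, is expected from the single numerical anchor, compound 3 at 1000 nM. The expected change is a 6.7-fold lower number from compound 3 to compound 4 (0.82 log units; beyond the scatter). For compound 4 the estimated value is 150 nM, with an expected range from 15 nM to 1500 nM.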

Compound 4, half-maximal inhibitory concentration: 500 nM
Beside the measured number, compound 4's estimate is 3.3-fold (0.52 log units) below it; measured number inside the range.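

Among the compounds shown here, the step gives the first single change that can be read: in this assay, it is a 2.0-fold lower number from compound 3 to compound 4 (0.30 log units; within the scatter), and this lies within the scatter. On this aromatic carbon, next to the ring nitrogen, 3-amino-4-methoxyphenyl and 4-bromophenyl therefore cannot be told apart by this read-out, even though the two groups differ in heavy atoms and in their counts of hydrogen-bond donors and acceptors. With the acetyl group held in place, the position accepts both aryl groups in this one pair, and no wider rule about substituents on this aryl ring follows from it.

Going by these compounds, compound 1 and compound 2 lack the acetyl group and offer a limit of the assay rather than a number, so neither can be set against this pair: the limit of > 50000 nM in this assay, at which 2 of the 4 values shown sit. Whether unsubstituted phenyl or a carboxylic acid on the aryl ring would keep the number in this range stays open, as does the part played by the acetyl group when 3-amino-4-methoxyphenyl occupies this position.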